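From Compound 2 to Compound 3: Adding Methoxy

The compounds below may be only part of what the source reports. "The series", "measured", "known", "first", "only" and "open" are said of these compounds alone.

In a functional assay on MCF7 cells (Homo sapiens) for antiproliferative activity, read by MTT assay, with a stated time of 48 h (on this read-out lower numbers stand for stronger inhibition and higher numbers for weaker inhibition), compound 1 (`O=C(/C=C/c1ccc(C(F)(F)F)cc1)Nc1nnc(-c2ccccc2)s1`) gives 1.52 ug/mL while compound 2 (`O=C(/C=C/c1ccccc1)Nc1nnc(-c2ccccc2)s1`) gives 1.47 ug/mL and so stands level with compound 1, within the scatter. Compound 3 (`COc1ccc(/C=C/C(=O)Nc2nnc(-c3ccccc3)s2)cc1`), not yet measured, differs from compound 2 by methoxy in place of hydrogen on an aromatic carbon, para to a large group (methoxy in place of hydrogen on an aromatic carbon). Among the measured compounds shown here, the one measured step that bears on this change concerns that same carbon: a 1.0-fold lower number from compound 1 to compound 2 (0.01 log units; within the scatter) with hydrogen in place of trifluoromethyl, a step that stayed within the scatter. For the measured compounds named here, no measured compound yet carries methoxy, so this evidence is thin. No step beyond the scatter is expected in this assay and no direction can be predicted. The expected change is correspondingly small (a 1.0-fold higher number from compound 2 to compound 3 (0.01 log units; within the scatter)). Compound 3 is estimated at 1.5 ug/mL with an expected range from 0.7 ug/mL to 3.5 ug/mL around that figure.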

Compound 3, half-maximal inhibitory concentration: 0.83 ug/mL
For compound 3 the middle estimate is 1.8-fold (0.26 log units) above the measured one; the measured number falls inside the stated range.
By their numbers in this assay, from the lowest: compounds 3, 2 and 1 (each within the scatter of the next).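

In this assay, among the compounds shown here, methoxy in place of hydrogen on this aromatic carbon gives a 1.8-fold lower number from compound 2 to compound 3 (0.25 log units; within the scatter) and so adds a first group with an oxygen atom at this position, still without a step beyond the scatter. Methoxy in place of trifluoromethyl gives a 1.8-fold lower number from compound 1 to compound 3 (0.26 log units; within the scatter) and also stays within the scatter, so hydrogen, trifluoromethyl and methoxy on this carbon all stand level on this read-out. Nothing is available that could account for these numbers.

The compounds shown leave open whether a group of another kind on this carbon, such as an amine, a carboxylic acid or a longer alkoxy chain, would give a step beyond the scatter. They also leave open how changes elsewhere on the shared core would read.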